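The source may report more compounds than this note shows. Statements on the series, on what has been measured and on what is new or still open speak of the compounds shown alone.

Measured compounds:
- compound 1 `N#CC1=C(N)N(c2ccc(S(N)(=O)=O)cc2)C2=C(CCCC2)C1c1ccccc1`: 5%
- compound 2 `COc1ccc(C2C(C#N)=C(N)N(c3ccc(S(N)(=O)=O)cc3)C3=C2CCCC3)cc1`: 50%
- compound 3 `N#CC1=C(N)N(c2ccc(S(N)(=O)=O)cc2)C2=C(CCCC2)C1c1cccc([N+](=O)[O-])c1`: 0%

In a functional assay on Ehrlich cells (Mus musculus) for cytotoxicity, read by trypan blue exclusion, with a stated time of 2 h, tested at 10 ug/mL (a higher number here means a stronger effect of the compound at the concentration tested, a lower number a weaker effect), compound 3 stands lowest of the three numbers. Its nearest neighbour is compound 1, with a number 5 percentage points lower from compound 1 to compound 3 (within the scatter); its furthest is compound 2, with a number 50 percentage points lower from compound 2 to compound 3 (beyond the scatter).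

Compound 4 `N#CC1=C(N)N(c2ccc(S(N)(=O)=O)cc2)C2=C(CCCC2)C1c1ccc(Cl)c(Cl)c1` differs from compound 3 by 3,4-dichlorophenyl in place of 3-nitrophenyl on a saturated ring carbon. Going by the values given here, no measured step carries a 3,4-dichlorophenyl. Among the compounds with values here, the steps that bear on it are a number 45 percentage points higher from compound 1 to compound 2 (beyond the scatter), a number 5 percentage points lower from compound 1 to compound 3 (within the scatter) and a number 50 percentage points lower from compound 2 to compound 3 (beyond the scatter): one large rise, one change within the scatter, one large drop. The only substituent on that aromatic ring that raised the read-out was the methoxy of compound 2. A step of about a number 15 percentage points higher from compound 3 to compound 4 (beyond the scatter) is expected, small and of uncertain direction. For compound 4 the estimate in this assay is 15%, within 0% to 45%.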

Compound 4, a percentage reported as activity, at one concentration (the size of the read-out at that concentration, not a potency): 1%
For compound 4 the middle estimate is 14 percentage points above the measured one, and the stated range covers the measured number.
By their numbers in this assay, from the lowest: compounds 3, 4 and 1 (each within the scatter of the next); then compound 2.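

At this saturated ring carbon in this assay, 3,4-dichlorophenyl gives a number 4 percentage points lower from compound 1 to compound 4 (within the scatter) and a number 1 percentage points higher from compound 3 to compound 4 (within the scatter) and so shows no separation from phenyl or 3-nitrophenyl. Against 4-methoxyphenyl the same group gives a number 49 percentage points lower from compound 2 to compound 4 (beyond the scatter) and leaves compound 2 alone above the other three. Nothing measured on hand accounts for this separation.

As far as these compounds go, whether the read-out of compound 2 depends on the methoxy itself remains open. A 4-hydroxyphenyl, 4-ethoxyphenyl or 4-dimethylaminophenyl at this carbon would address that.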